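A Further Methyl on Compound 3

The source may report more compounds than this note shows. Statements on the series, on what has been measured and on what is new or still open speak of the compounds shown alone.

Compound 1 `CCC(C)n1ncn(-c2ccc(N3CCN(c4ccc(OC[C@@H]5CO[C@@](CN6CCNCC6)(c6ccc(Cl)cc6Cl)O5)cc4)CC3)cc2)c1=O`: 608 nM
Compound 2 `CCC(C)n1ncn(-c2ccc(N3CCN(c4ccc(OC[C@@H]5CO[C@@](Cn6cnc(C(F)(F)F)n6)(c6ccc(Cl)cc6Cl)O5)cc4)CC3)cc2)c1=O`: 270 nM
Compound 3 `CCC(C)n1ncn(-c2ccc(N3CCN(c4ccc(OC[C@@H]5CO[C@@](Cn6ccnc6C)(c6ccc(Cl)cc6Cl)O5)cc4)CC3)cc2)c1=O`: 173 nM

In a functional assay on HUVEC cells (Homo sapiens), read by scintillation counting and thymidine incorporation, with a stated time of 24 h (a higher number here means a weaker inhibitor, a lower number a stronger inhibitor), the data show a 3.5-fold lower number from compound 1 to compound 3 (0.55 log units; beyond the scatter), but only a 1.6-fold lower number from compound 2 to compound 3 (0.19 log units; within the scatter). Compound 3 therefore shares the low end of the three values with compound 2. Compound 4 `CCC(C)n1ncn(-c2ccc(N3CCN(c4ccc(OC[C@@H]5CO[C@@](Cn6cc(C)nc6C)(c6ccc(Cl)cc6Cl)O5)cc4)CC3)cc2)c1=O` differs from compound 3 by methyl in place of hydrogen on an aromatic carbon, turning 2-methyl-1H-imidazol-1-yl into 2,4-dimethyl-1H-imidazol-1-yl. Among the measured compounds shown here, no measured step adds a methyl to this ring. The closest evidence, a 1.6-fold lower number from compound 2 to compound 3 (0.19 log units; within the scatter), exchanges the whole group and stays small. No step beyond the scatter is therefore expected, and the estimated change is a 1.0-fold lower number from compound 3 to compound 4 (0.01 log units; within the scatter). The expected value for compound 4 is 170 nM, with an estimated range from 85 nM to 340 nM.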

Compound 4, half-maximal inhibitory concentration: 492 nM
For compound 4 the middle estimate is 2.9-fold (0.46 log units) below the measured one; the whole stated range lies below it.
By their numbers in this assay, from the lowest: compounds 3, 2, 4 and 1 (each within the scatter of the next, the first and the last beyond it).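

In this assay the added methyl, a single heavy atom on this aromatic carbon, gives a 2.8-fold higher number from compound 3 to compound 4 (0.45 log units; beyond the scatter) and so shows that this ring position responds to a small change. The remaining comparisons read a 1.8-fold higher number from compound 2 to compound 4 (0.26 log units; within the scatter) and a 1.2-fold lower number from compound 1 to compound 4 (0.09 log units; within the scatter), so compound 4 no longer keeps the separation from compound 1 that compound 3 has. No measurement shown here accounts for the step. As far as these compounds go, whether ethyl, chlorine or an amine on this carbon would act as methyl does stays open, as does whether the step would hold on an imidazole lacking the 2-methyl group.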